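The source may hold more compounds than are shown below. What is called first, only, known or untested is meant among the compounds shown, and "the series" means these compounds.

Measured so far:
- Compound 3, `N#Cc1cccc(C#Cc2csc(N)n2)c1`, in an assay on brain for displacement of a labelled ligand from metabotropic glutamate receptor 5 (Rattus norvegicus) (a higher number here means a weaker inhibitor, a lower number a stronger inhibitor), gives 0.9 nM.
- Compound 1, `COc1cccc(C#Cc2csc(Cl)n2)c1`, in this assay gives 8.1 nM.
- Compound 2, `COc1cccc(C#Cc2csc(F)n2)c1`, in this assay gives 22.7 nM.

Compound 3 stands lowest of the three numbers. For the measured compounds named here, the only measured step, a 2.8-fold higher number from compound 1 to compound 2 (0.45 log units; beyond the scatter), concerns the five-membered ring and not the six-membered one. Compound 4, `COc1cccc(C#Cc2csc(N)n2)c1`, differs from compound 3 by methoxy in place of cyano on an aromatic carbon. Going by the values given here, no measured step covers this change; compounds 1 and 2 carry the methoxy group but also differ from compound 3 at the other ring, so their values alone cannot settle the direction. A modest step is expected, given as a 4.4-fold higher number from compound 3 to compound 4 (0.65 log units; beyond the scatter), most likely toward a higher number. Compound 4 is therefore estimated at 4 nM, within 1 nM to 15 nM.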

Compound 4, inhibition constant: 18.6 nM
The estimate for compound 4 lay 4.7-fold (0.67 log units) below the measured number; the whole stated range lies below it.
By their numbers in this assay, from the lowest: compound 3; then compound 1; then compounds 4 and 2 (each within the scatter of the next).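

In this assay, for the compounds shown here, methoxy in place of cyano gives a 21-fold higher number from compound 3 to compound 4 (1.32 log units; beyond the scatter) and so shows, for the first time, that this carbon of the six-membered aromatic ring responds strongly to the group it carries. On the other ring, amino in place of fluoro gives a 1.2-fold lower number from compound 2 to compound 4 (0.09 log units; within the scatter) and amino in place of chloro gives a 2.3-fold higher number from compound 1 to compound 4 (0.36 log units; beyond the scatter) and both are much smaller than the step at the six-membered ring. Nothing shown here accounts for these steps.

From the compounds shown here alone, whether an amide, a carboxylic acid or trifluoromethyl on this carbon would match cyano remains open. So does whether the step between cyano and methoxy keeps its size with chloro or fluoro on the other ring.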